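The source may hold more compounds than are shown below. What is called first, only, known or untested is meant among the compounds shown, and "the series" means these compounds.

Among the three measured compounds, compound 3 `CC(C)=CCOc1ccccc1C1CC(=O)c2ccccc2O1` carries the lowest of the numbers in a functional assay on J774.A1 cells (Mus musculus) for inhibition, read by immunoassay, with a stated time of 12 h, tested at 30 uM (a higher number here means more inhibition at the concentration tested (going by the name of the read-out), a lower number less inhibition), giving 40.3%, though its distance to compound 2 `C=CCOc1ccccc1C1CC(=O)c2ccccc2O1`, which gives 47%, lies within the scatter. The furthest from it is compound 1 `O=C1CC(c2ccccc2OCc2ccccc2)Oc2ccccc21`, which gives 91.5%. Compound 4 `CC(C)c1ccc(COc2ccccc2C2CC(=O)c3ccccc3O2)cc1` differs from compound 3 by 4-isopropylphenyl in place of 2-methylprop-1-en-1-yl on a saturated chain carbon bound to an oxygen on an aromatic ring. Within the data shown here, the steps that bear on this are a number 44.5 percentage points lower from compound 1 to compound 2 (beyond the scatter) and a number 51.2 percentage points lower from compound 1 to compound 3 (beyond the scatter), both large falls when phenyl gave way to vinyl or to 2-methylprop-1-en-1-yl, while a number 6.7 percentage points lower from compound 2 to compound 3 (within the scatter) stayed within the scatter. Compound 4 puts a six-membered aromatic ring of carbon only back onto that carbon, so a large rise is expected, a number 44.7 percentage points higher from compound 3 to compound 4 (beyond the scatter). Compound 4 is therefore estimated at 85%, with a range from 65% to 98%.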

Compound 4, a percentage reported as inhibition, at one concentration (the size of the read-out at that concentration, not a potency): 91.7%
For compound 4 the middle estimate is 6.7 percentage points below the measured one; the measured number falls inside the stated range.
By their numbers in this assay, from the lowest: compounds 3 and 2 (each within the scatter of the next); then compounds 1 and 4 (each within the scatter of the next).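

In this assay, the 4-isopropylphenyl group on this saturated chain carbon keeps the level seen with phenyl, as isopropyl in place of hydrogen on an aromatic carbon gives (a number 0.2 percentage points higher from compound 1 to compound 4 (within the scatter)). The large gap to the groups with a double bond also holds (a number 51.4 percentage points higher from compound 3 to compound 4 (beyond the scatter); a number 44.7 percentage points higher from compound 2 to compound 4 (beyond the scatter)), so among these four compounds, the two with an aromatic ring at this place stand apart from the two without one. No evidence given here explains this split. As far as these compounds go, whether a ring carrying an amine or a carboxylic acid, or a saturated longer chain, would keep the higher number remains open.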